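The compounds below may be only part of what the source reports. "The series", "measured", "known", "first", "only" and "open" are said of these compounds alone.

Compound 1, `CCOC(=O)c1c(C)coc1-c1ccc2c(CC)cccc2c1OC`, gives 1.8 ug/mL in a functional assay on KBVIN cells (Homo sapiens) for cytotoxicity, read by MTT assay, with a stated time of 72 h; on this read-out higher numbers stand for an effect only at larger amounts of compound and lower numbers for an effect already at smaller amounts.
Compound 2, `CCc1cccc2c(OC)c(-c3occ(C)c3C(=O)NC)ccc12`, gives only a limit of the assay, > 10 ug/mL, in this assay.
Compound 3, `CCc1cccc2c(OC)c(-c3occ(C)c3CBr)ccc12`, likewise gives only a limit, > 10 ug/mL, in this assay.

Compound 3 thus stands at the limit of the assay, as the limit of > 10 ug/mL in this assay, at which 2 of the 3 values shown sit, shows; no number is known for it, only that its effect needs more compound than the assay covers. Compound 4, `CCc1cccc2c(OC)c(-c3occ(C)c3COCC(F)(F)F)ccc12`, differs from compound 3 in one place: 2,2,2-trifluoroethoxy in place of bromo on a saturated chain carbon bound to an aromatic carbon. Among the compounds with values here, no measured step carries this same change. The measured steps that reach compound 3 are an at least 5.5-fold higher number from compound 1 to compound 3 (0.74 log units; beyond the scatter) and a step that the two limits leave unreadable from compound 2 to compound 3. Both end at the limit, so they fix only the starting point of the step to compound 4 and cannot size it. The expectation for compound 4 is therefore a result at or near the limit again, with a step that the limit leaves unreadable from compound 3 to compound 4 expected in this assay. Compound 4 is estimated at 12 ug/mL, in the range 4 ug/mL to 30 ug/mL, with a limit the most likely outcome.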

Compound 4, concentration for half-maximal effect: 6 ug/mL
Compound 4: the middle estimate sits 2.0-fold (0.30 log units) above what was measured; the range from low to high includes it.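

At this saturated chain carbon bound to an aromatic carbon, 2,2,2-trifluoroethoxy in place of bromo gives a measured number rather than a limit in this assay, so a compound without ethoxycarbonyl can still register in the range this read-out covers, unlike those that remain at the limit: the limit of > 10 ug/mL in this assay, at which 2 of the 4 values shown sit.

The size of this change stays loosely fixed, as the steps read an at least 1.6-fold lower number from compound 3 to compound 4 (0.22 log units; that floor lies within the scatter) and an at least 1.6-fold lower number from compound 2 to compound 4 (0.22 log units; that floor lies within the scatter), and each gives only a smallest possible size. Compound 1 still keeps the lower number, with a 3.3-fold higher number from compound 1 to compound 4 (0.52 log units; beyond the scatter), so (2,2,2-trifluoroethoxy)methyl does not match ethoxycarbonyl on this aromatic carbon.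

A plain ethoxy group at the same chain carbon would help separate the part played by the fluorine atoms from that of the oxygen. From the compounds shown here alone, how an amine or a carboxylic acid there would read in this assay also stays open.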